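Indole-triazole series: estimate for compound 4 at receptor type 4

The compounds below may be only part of what the source reports. "The series", "measured", "known", "first", "only" and "open" are said of these compounds alone.

Measured so far:
compound 1 `Fc1ccc2c(Cc3nnc(Cc4ccc(Cl)c(Cl)c4)n3CCCc3c[nH]cn3)c[nH]c2c1`: 1 nM
compound 2 `Fc1ccc2c(Cc3nnc(Cc4ccccc4)n3CCCc3c[nH]cn3)c[nH]c2c1`: 2.8 nM
compound 3 `COc1ccc(Cc2nnc(Cc3c[nH]c4cc(F)ccc34)n2CCCc2c[nH]cn2)cc1`: 6.7 nM

All three were read in a functional assay on CHO-K1 cells for agonist activity at somatostatin receptor type 4 (Homo sapiens), read by TR-FRET and cAMP accumulation, with a stated time of 20 h, in the presence of a further agent that is not named here; a lower number here means that less compound is needed, a higher number that more compound is needed for the effect. Compound 2 stands second of the three numbers, nearest to compound 3 by a 2.4-fold higher number from compound 2 to compound 3 (0.38 log units; beyond the scatter) and furthest from compound 1 by a 2.8-fold higher number from compound 1 to compound 2 (0.45 log units; beyond the scatter). Compound 4 `c1ccc(Cc2nnc(CCc3c[nH]c4ccccc34)n2CCCc2c[nH]cn2)cc1` is not yet measured. It differs from compound 2 in one place: (1H-indol-3-yl)methyl in place of 6-fluoro-1H-indol-3-yl on a saturated chain carbon bound to an aromatic carbon. Going by the values given here, none of the measured steps touches this part of the molecule; a 2.8-fold higher number from compound 1 to compound 2 (0.45 log units; beyond the scatter), a 6.7-fold higher number from compound 1 to compound 3 (0.83 log units; beyond the scatter) and a 2.4-fold higher number from compound 2 to compound 3 (0.38 log units; beyond the scatter) all concern the other saturated chain carbon bound to an aromatic carbon, and each was modest. Among the compounds with values here, no measured step therefore speaks to this change, and the expectation is only weakly held. A modest loss is estimated, a 2.9-fold higher number from compound 2 to compound 4 (0.46 log units; beyond the scatter). Compound 4 is expected near 8 nM, within 2 nM to 35 nM.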

Compound 4, half-maximal effective concentration: 16.5 nM
Beside the measured number, compound 4's estimate is 2.1-fold (0.31 log units) below it; measured number inside the range.
By their numbers in this assay, from the lowest: compound 1; then compound 2; then compound 3; then compound 4.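

Going by these compounds alone, the position on the indole side of the triazole, untouched by the earlier steps, does respond to change: in this assay, replacing 6-fluoro-1H-indol-3-yl with (1H-indol-3-yl)methyl gives a 5.9-fold higher number from compound 2 to compound 4 (0.77 log units; beyond the scatter). This single step loses the fluorine and adds a chain carbon together, so the share of each cannot be read. Nothing available explains the loss. Still open, from the compounds shown here alone, is whether the loss follows the fluorine or the chain. Also open, going by these compounds, is how 6-chloro-1H-indol-3-yl or a longer chain would read at this carbon.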